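This account rests on a few compounds, and the source may have more. Where it says the series, first, only, none or still open, it means among the compounds named here.

Compound 1 `COc1ccc(-c2ccc3c(NCCCNCc4cccc(OC)c4O)ccnc3c2)cc1` and compound 2 `COc1ccc(-c2ccc3c(NCCCNCc4ccco4)ccnc3c2)cc1` share a core and differ only in the group on a saturated chain carbon bound to an amine nitrogen. In a physicochemical assay for acid dissociation, compound 1 gives 9.47, and compound 2 gives 9.47. The step of no change at the digits printed from compound 1 to compound 2 (within the scatter) shows that swapping that group left the reading unchanged within the scatter, so compound 1 stands level with compound 2. Within the data shown here, compound 3 `COc1ccc(Oc2ccc3c(NCCCNCc4cccc(OC)c4O)ccnc3c2)cc1` differs from compound 1 elsewhere: 4-methoxyphenoxy in place of 4-methoxyphenyl on an aromatic carbon This change sits on the fused ring system rather than on the chain carbon bound to the amine nitrogen, and no measured step probes that place. Among the measured compounds shown here, the only known step shows one change away from the amine leaving the reading unchanged, so no step beyond the scatter is expected for compound 3, a number 0.02 log units lower from compound 1 to compound 3 (within the scatter). Compound 3 is therefore estimated at 9.45, within a range from 9.15 to 9.75.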

Compound 3, acid dissociation constant: 9.28
For compound 3 the middle estimate is 0.17 log units above the measured one; measured number inside the range.
By their numbers in this assay, from the lowest: compounds 3, 1 and 2 (each within the scatter of the next).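

In this assay, among these compounds, the swap of 4-methoxyphenyl for 4-methoxyphenoxy on an aromatic carbon of the shared core gives a number 0.19 log units lower from compound 1 to compound 3 (within the scatter) and this is the first reading of a change at this place. The earlier pair varied only the group on the chain carbon bound to the amine nitrogen, whereas this step shows that a second place can also take a change, here one that adds a single oxygen, without a shift beyond the scatter. Nothing available here offers an explanation for this reading.

From the compounds shown here alone, whether an amine or a carboxylic acid on this aromatic carbon would move the reading beyond the scatter remains open. Also open, going by these compounds, is whether 4-methoxyphenoxy would read the same with furan-2-yl on the chain carbon.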